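The source may report more compounds than this note shows. Statements on the series, on what has been measured and on what is new or still open speak of the compounds shown alone.

Measured so far in an assay on isolated protein for inhibition of Neprilysin (Oryctolagus cuniculus); a lower number here means a stronger inhibitor, a higher number a weaker inhibitor:
- compound 1, `C[C@H](NC(=O)[C@@H](S)Cc1ccccc1)C(=O)N1[C@@H](c2ccccc2)CC[C@H]1C(=O)O`: 10 nM
- compound 2, `CC[C@H](C)C(S)C(=O)NCC(=O)N1[C@@H](c2ccccc2)CC[C@H]1C(=O)O`: 50 nM

Compound 2 stands at the highest of the two numbers in this assay; the nearest is compound 1 with a number well below it, a gap beyond the scatter. Compound 3, `O=C(NCC(=O)N1[C@@H](c2ccccc2)CC[C@H]1C(=O)O)[C@@H](S)Cc1ccc(O)cc1`, is not yet measured. It differs from compound 2 by a group of 10 heavy atoms (8 carbon, 1 oxygen, 1 sulfur; one six-membered aromatic ring of carbon only) in place of a group of 6 heavy atoms (5 carbon, 1 sulfur; no ring), on a carbonyl carbon. Among the measured compounds shown here, no step between measured compounds covers this change; from compound 1, which carries a related ring-bearing side chain at that carbonyl, a shift toward a lower number is expected. The estimated step is a 3.3-fold lower number from compound 2 to compound 3 (0.52 log units; beyond the scatter). Compound 3 is expected to give 15 nM, within 5 nM to 50 nM.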

Compound 3, half-maximal inhibitory concentration: 3.4 nM
Compound 3: middle estimate off by 4.4-fold (0.64 log units), on the high side; measured number outside the range, below it.
By their numbers in this assay, from the lowest: compound 3; then compound 1; then compound 2.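

In this assay, the position on the carbonyl carbon whose other neighbour is the amide-type nitrogen is sensitive to the group it carries: replacing the ring-free group of 6 heavy atoms with the group of 10 heavy atoms bearing a six-membered aromatic ring gives a 15-fold lower number from compound 2 to compound 3 (1.17 log units; beyond the scatter) in one change. Among the compounds shown here, this is the first step read at this position. Nothing measured here bears on the reason for this step. The compounds shown leave open how much of the step belongs to the ring itself and how much to its hydroxyl. An unsubstituted phenyl, or an amine or carboxylic acid in place of that hydroxyl, would separate the two.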